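The source may hold more compounds than are shown below. What is called first, only, known or untested is meant among the compounds shown, and "the series" means these compounds.

In a functional assay on the whole organism for inhibition, with Mus musculus as the target (a lower number here means that less compound is needed, a higher number that more compound is needed for the effect), compound 1 (`CC(C)C1CCSC1=O`) gives 145 mg/kg. Compound 2 (`CC(C)C1(C)CCSC1=O`) gives 154 mg/kg, and the two values lie within the scatter of each other. Going by the values given here, the one measured step, a 1.1-fold higher number from compound 1 to compound 2 (0.03 log units; within the scatter), is methyl in place of hydrogen on a saturated ring carbon.

Compound 3 (`CC(C)C1(C(C)C)CCSC1=O`) has not yet been measured. It differs from compound 2 by isopropyl in place of methyl on a saturated ring carbon, which is isopropyl in place of methyl on a saturated ring carbon, two ring bonds from the ring sulfur. Among the compounds with values here, only one measured step bears on this change, and it concerns the same saturated ring carbon. That step, a 1.1-fold higher number from compound 1 to compound 2 (0.03 log units; within the scatter), stays within the scatter, so it gives no ground for expecting a shift in either direction in this assay. Within the data shown here, the support is thin, however, since no measured pair shows isopropyl in place of methyl. No step beyond the scatter is therefore expected, and the estimated step is a 1.0-fold lower number from compound 2 to compound 3 (0.01 log units; within the scatter). For compound 3 the expected value is 150 mg/kg, with an estimated range of 75 mg/kg to 300 mg/kg.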

Compound 3, dose for half-maximal effect: > 500 mg/kg
Compound 3: a limit, no number; the forecaster's own chance of this, stated with the estimate: 10%; at least 3.3-fold (0.52 log units) between middle value and limit.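

Compound 3 carries a limit of the assay rather than a number in this assay: the limit of > 500 mg/kg in this assay, at which 1 of the 3 values shown sits.

This saturated ring carbon, two ring bonds from the ring sulfur, had seemed indifferent to its substituent, since methyl in place of hydrogen stayed within the scatter, with a 1.1-fold higher number from compound 1 to compound 2 (0.03 log units; within the scatter). Isopropyl in place of methyl shows that the position does respond to a change of group, with an at least 3.2-fold higher number from compound 2 to compound 3 (0.51 log units; beyond the scatter), and isopropyl in place of hydrogen gives a step of similar reach, with an at least 3.4-fold higher number from compound 1 to compound 3 (0.53 log units; beyond the scatter), a rise beyond the scatter that methyl in that place did not produce.

As far as these compounds go, as one end of each new step is a limit, the full size of both steps remains unknown, and the three compounds cannot show how the response grows from one group to the next. From the compounds shown here alone, it also stays open whether ethyl on this carbon would keep the number near that of compound 2 or push it towards the limit of compound 3, and whether a hydroxyl or an amine there would behave like the carbon groups.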